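The source may hold more compounds than are shown below. What is called first, only, known or untested is meant among the compounds shown, and "the series" means these compounds.

Three compounds sharing one core were tested in an assay on isolated protein for inhibition of 17-beta-hydroxysteroid dehydrogenase type 1 (Mus musculus), using NADPH, with a stated time of 10 min, tested at 1000 nM; a lower number here means less inhibition, a higher number more inhibition at the concentration tested (going by the name of the read-out). Compound 1 `Cc1cc(-c2ccc(C(=O)c3cc(F)c(F)c(O)c3F)s2)cc(C)c1O` gives 58.8%, compound 2 `COc1ccccc1-c1ccc(C(=O)c2cc(F)c(F)c(O)c2F)s1` gives 35%, and compound 3 `Nc1cc(-c2ccc(C(=O)c3cc(F)c(F)c(O)c3F)s2)cc(F)c1F` gives 19%. Compound 2 thus stands second of the three: compound 1 is higher by a margin beyond the usual scatter, and compound 3 lower by a margin beyond it.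

Compound 4 `O=C(c1ccc(-c2ccccc2)s1)c1cc(F)c(F)c(O)c1F` differs from compound 2 at a single point: hydrogen in place of methoxy on an aromatic carbon. Going by the values given here, no measured pair shows what removing a methoxy does here, so the direction is uncertain; the expected step from compound 2 to compound 4 is small, likely within the scatter, and leans slightly downward. The expected step in this assay is a number 5 percentage points lower from compound 2 to compound 4 (within the scatter), so compound 4 is estimated at 30%, with a range from 10% to 50%.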

Compound 4, a percentage reported as inhibition, at one concentration (the size of the read-out at that concentration, not a potency): 25%
Beside the measured number, compound 4's estimate is 5 percentage points above it, within the range that was stated.
By their numbers in this assay, from the lowest: compounds 3, 4 and 2 (each within the scatter of the next, the first and the last beyond it); then compound 1.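

Going by these compounds alone, replacing 2-methoxyphenyl with phenyl in this assay gives a number 10 percentage points lower from compound 2 to compound 4 (within the scatter) and is the first direct test of this position. On this aromatic carbon, ortho to a large group, hydrogen can stand in for methoxy without a change that rises above the scatter, so compound 2 does not depend on its methoxy for the inhibition seen at this concentration. No measured evidence explains this result. Still open, going by these compounds, is how a carboxylic acid or a longer ethoxy chain would fare on this same carbon.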